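Fixing One Stereocentre in a Quinuclidine-Triazole Series

This account rests on a few compounds, and the source may have more. Where it says the series, first, only, none or still open, it means among the compounds named here.

Measured so far:
compound 1, `Fc1ccc(-c2cn(C3CN4CCC3CC4)nn2)cc1`, 8.5 nM
compound 2, `Oc1ccc(-c2cn(C3CN4CCC3CC4)nn2)cc1`, 3.44 nM
compound 3, `FCCCOc1cccc(-c2cn([C@@H]3CN4CCC3CC4)nn2)c1`, 19.5 nM

In an assay on HEK293 cells for displacement of a labelled ligand from Neuronal acetylcholine receptor; alpha3/beta4 (Homo sapiens), read by scintillation counting, with a stated time of 120 min (a lower number here means a stronger inhibitor, a higher number a weaker inhibitor), compound 1 stands second highest of the three numbers. Within the data shown here, the closest is compound 3 with 19.5 nM, and the furthest is compound 2 with 3.44 nM, the only step recorded here: a 2.5-fold lower number from compound 1 to compound 2 (0.39 log units; beyond the scatter), a change of the group on the aromatic carbon.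

Compound 4, `Fc1ccc(-c2cn([C@H]3CN4CCC3CC4)nn2)cc1`, is not yet measured. The change from compound 1 is the two compounds have the same atoms and bonds; at least one stereo element is drawn with a configuration in one of them and without one in the other: 1 of 3 stereo elements differ; a stereocentre at a saturated ring carbon is drawn without a configuration in compound 1 and R in compound 4. No atom leaves and none enters; one stereocentre at a saturated ring carbon is simply given a single drawn configuration where compound 1 has none.

Among the measured compounds shown here, none of the measured steps resolves this kind of change: the step from compound 1 to compound 2 alters a substituent, not a stereocentre, and compound 3 carries a drawn configuration only together with a different side chain, so its number alone cannot separate the two effects. A mixture drawn without configuration generally gives a number that sits between those of its two pure forms. If compound 4 is the stronger of the pair, its number should fall somewhat; if it is the weaker, it could rise considerably.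

Weighing that, compound 4 is expected at 6 nM in this assay, within 2.5 nM to 40 nM, which means an expected step of a 1.4-fold lower number from compound 1 to compound 4 (0.15 log units; within the scatter).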

Compound 4, inhibition constant: 1010 nM
Compound 4: the middle estimate sits 170-fold (2.23 log units) below what was measured; measured number outside the range, above it.
By their numbers in this assay, from the lowest: compound 2; then compound 1; then compound 3; then compound 4.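

Fixing the stereocentre as R gives a 120-fold higher number from compound 1 to compound 4 (2.07 log units; beyond the scatter) in this assay, a far larger change than the one from swapping the group on the aromatic carbon, which gave a 2.5-fold lower number from compound 1 to compound 2 (0.39 log units; beyond the scatter). This shows that the spatial arrangement at this saturated ring carbon can matter much more here than that substituent, and that the R form is not where the strength of compound 1 lies: if compound 1 is a mixture of both forms, most of its strength must come from the form other than compound 4. The gap can be traced to this one place alone, because the atoms and bonds of the two compounds are identical and only one thing separates them: the fact that one of compounds 1 and 4 is drawn with a defined configuration and the other without, at the place where they differ.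

As far as these compounds go, what remains open is the number for the pure opposite form of compound 1, and whether compound 2 shows the same strong preference between its two forms. From the compounds shown here alone, it is also open whether that preference would hold with an amine or a carboxylic acid on the aromatic ring in place of the fluoro or hydroxy group.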